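A bromopyridinyl amide set against its phenyl parent

The source may report more compounds than this note shows. Statements on the series, on what has been measured and on what is new or still open speak of the compounds shown alone.

Three amides on a shared core have been measured in an assay on CHO cells, read by calcium flux; a higher number here means a weaker inhibitor, a lower number a stronger inhibitor. Compound 1 `CC(C)(C)c1ccc(NC(=O)c2csc(Cc3c(Cl)cccc3Cl)n2)cc1` gives 300 nM in this assay. Compound 3 `O=C(Nc1ccc(C(F)(F)C(F)(F)F)cc1)c1csc(Cc2c(Cl)cccc2Cl)n1` gives 350 nM in this assay, and the step of a 1.2-fold higher number from compound 1 to compound 3 (0.07 log units; within the scatter). Compound 2 `O=C(Nc1ccccc1)c1csc(Cc2c(Cl)cccc2Cl)n1` reaches only a limit of the assay, > 4000 nM in this assay, so compound 2 stands at the weak end of the numbers shown and its true value is open (the limit of > 4000 nM in this assay, at which 1 of the 3 values shown sits). The measured steps of an at least 13-fold higher number from compound 1 to compound 2 (1.12 log units; beyond the scatter) and an at least 11-fold lower number from compound 2 to compound 3 (1.05 log units; beyond the scatter) are both large, with a tert-butyl or a 1,1,2,2,2-pentafluoroethyl group on the aromatic carbon standing far below the limit.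

Compound 4 `O=C(Nc1ccc(Br)cn1)c1csc(Cc2c(Cl)cccc2Cl)n1` is not yet measured. It differs from compound 2 by 5-bromopyridin-2-yl in place of phenyl on an amide-type nitrogen. Within the data shown here, no measured step covers this change: bromine is a different group from tert-butyl or 1,1,2,2,2-pentafluoroethyl, and the ring nitrogen has no counterpart among compounds 1 to 3. Given the two large steps away from the limit, a smaller step down is expected: an at least 2.6-fold lower number from compound 2 to compound 4 (0.42 log units; beyond the scatter), with a fair chance that compound 4 again reaches only the limit. The estimate for compound 4 is 1500 nM, between 400 nM and 6000 nM.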

Compound 4, half-maximal inhibitory concentration: > 4000 nM
Compound 4: a limit, no number; the forecaster's own chance of this, stated with the estimate: 30%; middle value at least 2.6-fold (0.42 log units) away from the limit.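

In this assay compound 4 gives > 4000 nM and this is a limit of the assay. Among these compounds, compound 2 sits at a limit too, so no step from compound 2 to compound 4 can be read: the limit of > 4000 nM in this assay, at which 2 of the 4 values shown sit. The compounds shown leave open whether 5-bromopyridin-2-yl in place of phenyl changes the true value at all.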